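The compounds below may be only part of what the source reports. "The series", "measured", "known", "first", "only" and "open" are said of these compounds alone.

Measured compounds in a functional assay on HOP-92 cells (Homo sapiens) for inhibition, read by sulforhodamine B assay, with a stated time of 48 h; on this read-out lower numbers stand for higher toxicity in this test and higher numbers for lower toxicity in this test:

- Compound 1 `COc1ccc(CNc2nc3cc(N)cc(N)c3nc2-c2ccccc2)cc1OC` gives 66100 nM in this assay.
- Compound 2 `COc1cc(CNc2nc3cc(N)cc(N)c3nc2-c2ccccc2)cc(OC)c1OC` reaches only the limit of < 50200 nM in this assay; that is a limit, not a number.
- Compound 3 `CCOC(=O)[C@H](CCC(=O)O)NC(=O)c1ccc(Oc2nc3cc(N)cc(N)c3nc2-c2ccccc2)cc1` reaches only the limit of < 100000 nM in this assay; that is again a limit, not a number.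

Among the measured compounds shown here, compound 1 thus stands as the only compound of the three with a definite number in this assay; the other two values are limits and cannot be ranked against it.

Compound 4 `COc1ccc(CNc2nc3cc(N)cc(N)c3nc2-c2ccccc2)cc1` differs from compound 1 by hydrogen in place of methoxy on an aromatic carbon, ortho to a methoxy group and meta to a large group; one bond further out, 3,4-dimethoxyphenyl becomes 4-methoxyphenyl.

For the measured compounds named here, only one measured step touches this change, and in the opposite direction: an at least 1.3-fold lower number from compound 1 to compound 2 (0.11 log units; that floor lies within the scatter), a methoxy added to an aromatic carbon, which sits within the usual scatter, and its floor is a limit. Removing a methoxy is therefore expected to give no step beyond the scatter; the step of a 1.1-fold higher number from compound 1 to compound 4 (0.05 log units; within the scatter) is the estimate.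

Compound 4 is estimated at 75000 nM in this assay, with a range from 30000 nM to 190000 nM.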

Compound 4, concentration lethal to 50% of the cells: < 100000 nM
Compound 4: no number, only a limit; the forecaster's own chance of this, stated with the estimate: 30%; the middle value does not contradict the limit.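

In this assay, among the compounds shown here, compound 4 gives < 100000 nM, which is a limit and not a number, so no step from compound 1 to compound 4 can be read. The compounds shown leave open whether 3,4-dimethoxyphenyl and 4-methoxyphenyl differ at all in this test, with compound 3 and compound 4 sharing one limit: the limit of < 100000 nM in this assay, at which 2 of the 4 values shown sit.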